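The compounds below may be only part of what the source reports. "The series", "measured", "known", "first", "only" and "open" are said of these compounds alone.

Measured so far:
compound 1, `Cn1c(-c2ccc(NC(=O)CCl)cc2)nc(-c2ccccc2)c1-c1ccccc1`: 23.7%
compound 2, `Cc1nnc(SCC(=O)Nc2ccc(-c3nc(-c4ccccc4)c(-c4ccccc4)n3C)cc2)s1`: 83.3%

Two compounds carry a number in a functional assay on HT-29 cells (Homo sapiens) for cytotoxicity, read by MTT assay, with a stated time of 24 h, tested at 16 ug/mL; on this read-out lower numbers stand for a weaker effect and higher numbers for a stronger effect at the one concentration tested. Compound 1 gives 23.7% and compound 2 gives 83.3%; compound 2 therefore holds the highest of the two numbers, with compound 1 beyond the scatter below it. Among the measured compounds shown here, the single step recorded, a number 59.6 percentage points higher from compound 1 to compound 2 (beyond the scatter), puts the (5-methyl-1,3,4-thiadiazol-2-yl)sulfanyl group in place of chloro on a saturated chain carbon bound to a carbonyl carbon and is large.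

Compound 3, `Cn1c(-c2ccc(NC(=O)CSC3=NCCS3)cc2)nc(-c2ccccc2)c1-c1ccccc1`, has not been measured. It differs from compound 2 in one place: a group of 5 heavy atoms (3 carbon, 1 nitrogen, 1 sulfur; one five-membered non-aromatic ring with 2 hetero atoms) in place of a group of 6 heavy atoms (3 carbon, 2 nitrogen, 1 sulfur; one five-membered aromatic ring with 3 hetero atoms), on a sulfur. The sulfur on the saturated chain carbon stays; only the ring on it changes. For the measured compounds named here, no measured step compares two rings on that sulfur, so a number 59.6 percentage points higher from compound 1 to compound 2 (beyond the scatter) bears on it only indirectly: it shows that a sulfur-linked ring in place of chloro raised the number greatly, but not how much of that rests on the particular ring. The expectation is a modest downward step, a number 18.3 percentage points lower from compound 2 to compound 3 (beyond the scatter), with wide uncertainty. Compound 3 is thus estimated at 65% in this assay, within the range 35% to 90%.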

Compound 3, a percentage reported as activity, at one concentration (the size of the read-out at that concentration, not a potency): 43.3%
Compound 3: middle estimate off by 21.7 percentage points, on the high side; measured number inside the range.
By their numbers in this assay, from the lowest: compound 1; then compound 3; then compound 2.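

In this assay, the identity of the ring on the sulfur now proves decisive, not just the presence of a sulfur-linked ring: the step from the 5-methyl-1,3,4-thiadiazol-2-yl group to the non-aromatic five-membered ring with 2 hetero atoms is large (a number 40 percentage points lower from compound 2 to compound 3 (beyond the scatter)). The gain over chloro is therefore only partly retained, since the non-aromatic ring gives a modest step (a number 19.6 percentage points higher from compound 1 to compound 3 (beyond the scatter)) where the 5-methyl-1,3,4-thiadiazol-2-yl group gives a large one (a number 59.6 percentage points higher from compound 1 to compound 2 (beyond the scatter)). No available evidence accounts for the gap between these two rings.

The two rings differ in their aromaticity, their hetero atoms and the methyl group all at once, so these compounds leave open which of those differences matters, and a thiadiazole without the methyl, or a simple phenyl ring on the same sulfur, would help to separate them. Also open, from the compounds shown here alone, is whether the sulfur itself is needed, as a morpholine or another cyclic amine in place of chloro on the saturated chain carbon would show, and how the order of the compounds holds beyond the one concentration tested.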